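An iodo swap on the amide nitrogen of compound 3

A few compounds are considered here, and "the series" means these few. Any claim that something is new, unique, unknown or untested is made for them only; others in the source may bear on it.

In an ADME assay on WI-38 cells (Homo sapiens) for cytotoxicity, read by MTT assay, with a stated time of 72 h (a lower number here means a stronger inhibitor, a higher number a weaker inhibitor), compound 3 (`Cc1ccc(NC(=O)CCc2cccc3c2B(O)OC3)cc1`) reads only as a limit (> 100000 nM). Compound 1 (`O=C(CCc1cccc2c1B(O)OC2)Nc1ccc(Cl)cc1`) is also a limit (> 100000 nM), the level where most of these readings sit (the limit of > 100000 nM in this assay, at which 2 of the 3 values shown sit). Compound 2 (`O=C(CCc1cccc2c1B(O)OC2)Nc1ccc(I)cc1`) gives a real number (49000 nM). Compound 4 (`O=C(CCc1cccc2c1B(O)OC2)Nc1cccc(I)c1`) has 3-iodophenyl in place of 4-methylphenyl on an amide-type nitrogen. Going by the values given here, two measured steps bear on this change (an at least 2.0-fold higher number from compound 2 to compound 3 (0.30 log units; that floor lies within the scatter)) and (an at least 2.0-fold lower number from compound 1 to compound 2 (0.30 log units; that floor lies within the scatter)), and the floor of each lies within the scatter. A modest shift to a lower number is therefore expected (an at least 1.6-fold lower number from compound 3 to compound 4 (0.22 log units; that floor lies within the scatter)). Compound 4 is estimated at (60000 nM), with an expected range from (30000 nM) to (100000 nM).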

Compound 4, half-maximal inhibitory concentration: 71000 nM
Compound 4: the middle estimate sits 1.2-fold (0.07 log units) below what was measured; low and high end bracket the measured number.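

In this assay, 3-iodophenyl in place of 4-iodophenyl on the amide-type nitrogen gives a 1.4-fold higher number from compound 2 to compound 4 (0.16 log units; within the scatter), so the two iodo compounds cannot be told apart. The steps from the methyl and chloro compounds are an at least 1.4-fold lower number from compound 3 to compound 4 (0.14 log units; that floor lies within the scatter) and an at least 1.4-fold lower number from compound 1 to compound 4 (0.14 log units; that floor lies within the scatter), and neither floor clears the scatter. Compound 1 and compound 3 remain limits, not numbers: the limit of > 100000 nM in this assay, at which 2 of the 4 values shown sit.

Going by these compounds, what stays open is whether another group on this phenyl, such as an amine or a carboxylic acid, would give a reading clearly beyond the scatter.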